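Swapping a phenyl for ethyl on a benzotriazole urea

The source may report more compounds than this note shows. Statements on the series, on what has been measured and on what is new or still open speak of the compounds shown alone.

Measured compounds:
- compound 1, `O=C(NCCCCc1ccccc1)n1nnc2ccccc21`, gives > 2 h.
- compound 2, `Cc1nc2ccccc2n1C(=O)NCCCCc1ccccc1`, gives 0.133 h.
- compound 3, `Cc1ccccc1CNC(=O)n1cnc2ccccc21`, gives 1.37 h.

All three were run in a physicochemical assay for metabolic stability, read by HPLC, at pH 4.5, tested at 10 uM; a higher number here means that the compound lasts longer, a lower number that the compound disappears faster. Compound 1 stands at the top of the numbers shown. Its result of > 2 h is a limit of the assay and not a number: the compound had not disappeared far enough for a half-life to be read, as the limit of > 2 h in this assay, at which 1 of the 3 values shown sits, records. Compound 2 gives 0.133 h and compound 3 gives 1.37 h, but neither shares the core of compound 1, so their values show only where they sit and say nothing about the step taken here.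

Compound 4, `CCCCCCNC(=O)n1nnc2ccccc21`, keeps the core of compound 1 and its chain. The difference is ethyl in place of phenyl on a saturated chain carbon, four bonds along the chain from an amide-type nitrogen. Among the measured compounds shown here, no step between measured compounds touches this chain end, so there is no measured guide. The core, which carries the urea that the assay follows, is unchanged, and the change sits far out on the chain.

The step that the limit leaves unreadable from compound 1 to compound 4 is therefore expected to be none beyond the scatter. Compound 4 is expected to give 2.5 h, most likely again as a limit, with a range from 1.2 h to 5 h.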

Compound 4, half-life: > 2 h
Compound 4 ended at the assay's limit; the forecaster's own chance of this, stated with the estimate: 70%; the middle value is on the limit's open side.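

Compound 1 and compound 4 both sit at a limit of this assay rather than at a number, so no step from one to the other can be read: the limit of > 2 h in this assay, at which 2 of the 4 values shown sit.

The compounds shown leave open how long compound 1 and compound 4 really last, and whether ethyl in place of phenyl changes the half-life at all.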